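Removing a Fluoro Group: Expected Cytotoxicity of Compound 4

This account rests on a few compounds, and the source may have more. Where it says the series, first, only, none or still open, it means among the compounds named here.

Measured so far in a functional assay on KG-1 cells (Homo sapiens) for cytotoxicity, read by luminescence and CellTiter-Glo, with a stated time of 3 days; on this read-out higher numbers stand for weaker inhibition and lower numbers for stronger inhibition:
compound 1, `N#Cc1ccc(NC(=O)c2ccc3cccnc3c2O)c(F)c1`, 3260 nM
compound 2, `O=C(Nc1ccc(C(F)(F)F)cc1)c1cc(Br)c(F)cc1O`, 820 nM
compound 3, `N#Cc1ccc(NC(=O)c2ccc3cccnc3c2O)cc1`, 2320 nM

Compound 3 differs from compound 1 by hydrogen in place of fluoro on an aromatic carbon, and this gave a 1.4-fold lower number from compound 1 to compound 3 (0.15 log units; within the scatter). Compound 2 rests on a different core; the difference between the two cores is not broken down here. Its number is the lowest of the three.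

Compound 4, `O=C(Nc1ccc(C(F)(F)F)cc1)c1cc(Br)ccc1O`, differs from compound 2 by hydrogen in place of fluoro on an aromatic carbon. This is the same kind of change as that from compound 1 to compound 3, but at a different place: there the carbon was ortho to a large group and meta to a cyano group, here it is ortho to a bromo group, meta to a hydroxy group and para to a large group. A step of about a 1.2-fold lower number from compound 2 to compound 4 (0.07 log units; within the scatter) is expected in this assay, because the earlier removal of a fluoro group gave a 1.4-fold lower number from compound 1 to compound 3 (0.15 log units; within the scatter). Compound 4 is therefore estimated at 700 nM, with a likely range from 250 nM to 2000 nM.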

Compound 4, half-maximal inhibitory concentration: 610 nM
Compound 4: middle estimate off by 1.1-fold (0.06 log units), on the high side, and the stated range covers the measured number.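

Hydrogen in place of fluoro on an aromatic carbon gave a 1.3-fold lower number from compound 2 to compound 4 (0.13 log units; within the scatter) in this assay. Set beside the earlier step, the same change shows no detectable difference between the two cores: the same change on two cores in this assay, a 1.4-fold lower number (0.15 log units; within the scatter) from compound 1 to compound 3 and a 1.3-fold lower number (0.13 log units; within the scatter) from compound 2 to compound 4, 1.0-fold (0.02 log units) apart, within the scatter of two such steps. This supports carrying the change across these two cores as a small step, but since each step lies within the scatter, it does not show that removing the fluoro group has any real effect, nor that the agreement would extend to other cores.

From the compounds shown here alone, it remains open whether a methoxy group or an amine on the same aromatic carbon would shift the number. Also open, going by these compounds, is whether the step would stay as small with a chloro group in place of the bromo group.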